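The source may report more compounds than this note shows. Statements on the series, on what has been measured and on what is new or still open speak of the compounds shown alone.

Within the data shown here, compound 1 `Cc1n[nH]c(C(=O)O)c1Cc1ccc(Oc2ccccc2)cc1` gives 10% in an assay on isolated protein for inhibition of 2-Hydroxyacid oxidase 2 (Homo sapiens), tested at 1 uM (a lower number here means a weaker effect, a higher number a stronger effect of the compound at the concentration tested), the smaller of the two numbers so far, though the gap to compound 2 `Cc1n[nH]c(C(=O)O)c1Cc1cccc(-c2ccc(C(N)=O)cc2)c1`, which gives 18%, lies within the scatter. Compound 3 `Cc1n[nH]c(C(=O)O)c1Cc1ccc(C(=O)O)cc1` is not yet tested; against compound 1 it carries carboxy in place of phenoxy on an aromatic carbon. Among the measured compounds shown here, no pair of measured compounds shows what this change does, so any shift from compound 1 is expected to stay within the scatter, with no clear direction. For compound 3 the estimate in this assay is 12%, with a range from 0% to 30%. This corresponds to an expected step of a number 2 percentage points higher from compound 1 to compound 3 (within the scatter).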

Compound 3, a percentage reported as inhibition, at one concentration (the size of the read-out at that concentration, not a potency): 3%
Compound 3: the middle estimate sits 9 percentage points above what was measured; the range from low to high includes it.
By their numbers in this assay, from the lowest: compounds 3, 1 and 2 (each within the scatter of the next, the first and the last beyond it).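

In this assay, carboxy in place of phenoxy on an aromatic carbon, para to a large group, gives a number 7 percentage points lower from compound 1 to compound 3 (within the scatter). At this position, then, losing the phenoxy ring and placing carboxy there does not move the read-out beyond the scatter, and this single exchange gives no sign of a gain. No measured evidence accounts for this result.

As far as these compounds go, whether an amine or a longer alkyl chain at this position would move the read-out beyond the scatter remains open. Also open, from the compounds shown here alone, is whether changes elsewhere on the shared core would do so.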